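This account rests on a few compounds, and the source may have more. Where it says the series, first, only, none or still open, it means among the compounds named here.

Measured so far:
Compound 1, `O=[N+]([O-])c1ccc(/C=N/Cc2cccnc2)cc1` — 100 mg/kg in a functional assay on the whole organism (strain Swiss albino) with Mus musculus as the target, in the maximal electroshock model, with a stated time of 0.5 h; on this read-out lower numbers stand for an effect already at smaller amounts and higher numbers for an effect only at larger amounts of compound
Compound 2, `C/C(=N\Cc1cccnc1)c1ccccc1` — 100 mg/kg in this assay

On these numbers compound 2 stands level with compound 1: the two values are the same at the digits printed, so the difference lies within the scatter of repeated measurements, and no order between them can be read from the data.

Compound 3, `C/C(=N\Cc1cccnc1)c1cccc(N)c1`, differs from compound 2 in one place: amino in place of hydrogen on an aromatic carbon. Going by the values given here, no pair of measured compounds shows what this kind of change does on this read-out, so nothing in the data points in either direction. For compound 3 the step from compound 2 is therefore expected to be no change at the digits printed from compound 2 to compound 3 (within the scatter), that is, none beyond the scatter. Compound 3 is expected to give 100 mg/kg in this assay, with a likely range from 30 mg/kg to 300 mg/kg.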

Compound 3, minimum effective dose: 30 mg/kg
Estimate against measurement, compound 3: 3.3-fold (0.52 log units) above; low and high end bracket the measured number.
By their numbers in this assay, from the lowest: compound 3; then compounds 1 and 2 (each within the scatter of the next).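

In this assay, going by these compounds alone, amino in place of hydrogen on an aromatic carbon, meta to a large group, brings a 3.3-fold lower number from compound 2 to compound 3 (0.52 log units; beyond the scatter) and gives the first step that can be read beyond the scatter. This position on the six-membered aromatic ring of carbon only therefore responds to substitution: a group of one heavy atom placed there is enough to shift the effect to a smaller dose. Nothing measured here explains why this change has this result.

From the compounds shown here alone, it remains open whether this shift belongs to the amino group itself or would also follow from a hydroxyl, a methoxy or a methylamino group at the same place. Also open, going by these compounds, is whether amino would have the same effect on the other carbons of that ring.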